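This account rests on a few compounds, and the source may have more. Where it says the series, first, only, none or still open, it means among the compounds named here.

Among the measured compounds shown here, compound 3 `CCCCC(O)c1cccc(NC(=O)NC(=O)CCl)c1` is one of three compounds measured in a functional assay on HT-29 cells (Homo sapiens) for antiproliferative activity, with a stated time of 48 h; on this read-out higher numbers stand for weaker inhibition and lower numbers for stronger inhibition. Compound 3 gives 10000 nM, the second highest of the three numbers. Its nearest neighbour is compound 2 `CCCCCc1cccc(NC(=O)NC(=O)CCl)c1`, which gives 8400 nM in this assay; the two lie within the scatter of each other. The furthest is compound 1 `CCCCC(OC)c1cccc(NC(=O)NCCCCl)c1`, which gives 56000 nM in this assay, a gap beyond the scatter.

Compound 4 `CCCCC(OC)c1cccc(NC(=O)NC(=O)CCl)c1` has not yet been measured. It differs from compound 3 in one place: methyl in place of hydrogen on an oxygen on a saturated carbon, that is, hydroxy to methoxy, 1-hydroxypentyl to 1-methoxypentyl. For the measured compounds named here, compound 1 also carries a methoxy at this place, but it differs from compound 3 in a second place as well, so its number cannot be read as a step for this change; the two values show only that such a pair can lie beyond the scatter when the rest of the molecule differs too. Going by the values given here, only one measured step touches this place, the one in which hydroxy replaced hydrogen, and it left the number where it was. Because a 1.2-fold higher number from compound 2 to compound 3 (0.08 log units; within the scatter) stayed flat, the expected step is no change at the digits printed from compound 3 to compound 4 (within the scatter), none beyond the scatter in either direction. Compound 4 is therefore estimated to give 10000 nM in this assay, within a range from 4000 nM to 25000 nM.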

Compound 4, half-maximal inhibitory concentration: 10000 nM
The estimate for compound 4 equals the measured number at the digits printed; measured number inside the range.
By their numbers in this assay, from the lowest: compounds 2, 3 and 4 (each within the scatter of the next); then compound 1.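

In this assay the change of hydroxy to methoxy gives no change at the digits printed from compound 3 to compound 4 (within the scatter) and so leaves the number where it stood, while the comparison with the unsubstituted chain carbon gives a 1.2-fold higher number from compound 2 to compound 4 (0.08 log units; within the scatter) in the same terms. The flat result seen earlier for hydroxy therefore also holds for methoxy, and for these compounds neither group on this saturated chain carbon moves the number beyond the scatter. Compound 4 also allows compound 1 to be read as a single change, with the 1-methoxypentyl group held constant: (chloromethyl)carbonyl in place of 3-chloropropyl on the amide-type nitrogen gives a 5.6-fold lower number from compound 1 to compound 4 (0.75 log units; beyond the scatter) and is the only step here beyond the scatter, though nothing shown accounts for these numbers.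

The compounds shown leave open whether an amine or a carboxylic acid on this saturated chain carbon, or a chain longer than pentyl, would also leave the number flat. They also leave open whether hydroxy and methoxy would remain level with 3-chloropropyl on the amide-type nitrogen.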